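This account rests on a few compounds, and the source may have more. Where it says the series, first, only, none or still open, it means among the compounds named here.

Measured compounds in a functional assay on Ramos cells (Homo sapiens) for antiproliferative activity, read by CCK-8 assay, with a stated time of 24 h; a higher number here means a weaker inhibitor, a lower number a stronger inhibitor:
- compound 1 `C=CC(=O)Nc1cccc(Nc2ncnc(Nc3ccc(-c4cccnc4)cc3)n2)c1`: > 100000 nM, a limit of the assay rather than a number
- compound 2 `C=CC(=O)Nc1cccc(Nc2nc(Cl)nc(Nc3ccc(OCCOC)cc3)n2)c1`: "not determined" (no result reported)
- compound 3 `C=CC(=O)Nc1cccc(Nc2nc(Cl)nc(Nc3ccc(Oc4ccccc4)cc3)n2)c1`: 12300 nM

Compound 2 stands without a number in this assay. Of the three values shown for the series, one is the limit (the limit of > 100000 nM in this assay, at which 1 of the 3 values shown sits), which belongs to compound 1 and is a bound rather than a reading. For the measured compounds named here, compound 3, which shares the chloro substituent with compound 2, is the only compound with a measured value, and that value is weak. The series as a whole therefore gives little to anchor compound 2.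

Compound 4 `C=CC(=O)Nc1cccc(Nc2nc(N)nc(Nc3ccc(OCCOC)cc3)n2)c1` is made from compound 2 by the change amino in place of chloro on an aromatic carbon, on the ring with three nitrogen atoms, between two ring nitrogen atoms and opposite the ring nitrogen.

Going by the values given here, no measured pair shows what this change does. The expectation is a step of no more than modest size in this assay, in either direction, most likely not beyond the scatter, with weak inhibition on both sides. On that basis compound 4 is estimated at 30000 nM, with a range from 6000 nM to 100000 nM, and a fair chance that only a limit is reported.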

Compound 4, half-maximal inhibitory concentration: 18900 nM
Beside the measured number, compound 4's estimate is 1.6-fold (0.20 log units) above it, within the range that was stated.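

No step can be read from compound 2 to compound 4: in this assay compound 2 has no reported result, and compound 4 gives 18900 nM with no partner to compare against. What amino in place of chloro on an aromatic carbon does to antiproliferative activity stays open in the compounds shown. Nothing shown bears on the value of compound 4.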